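Stereochemical inversion at the chain carbinol of compound 2

The source may hold more compounds than are shown below. What is called first, only, known or untested is meant among the compounds shown, and "the series" means these compounds.

Measured so far:
- compound 1, `OC(CCn1nc2c(Br)c(Br)c(Br)c(Br)c2n1)c1ccc(Br)cc1`: in a functional assay on CCRF-CEM cells (Homo sapiens) for antiproliferative activity, read by MTT assay, with a stated time of 48 h, tested at 12.5 uM (a lower number here means a stronger effect, a higher number a weaker effect of the compound at the concentration tested), compound 1 gives 89%.
- compound 2, `C[C@@H](O)CCn1nc2c(Br)c(Br)c(Br)c(Br)c2n1`: in this assay compound 2 gives 94%.

Two compounds share the core of compound 1 and carry a hydroxylated chain on the ring nitrogen. The values of compound 2 and compound 1 lie within the scatter of each other, so no order between them can be read from these two numbers. Both sit at the weak end of the read-out at the concentration tested.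

Compound 3, `C[C@H](O)CCn1nc2c(Br)c(Br)c(Br)c(Br)c2n1`, has not yet been measured. The change from compound 2 is the two compounds have the same atoms and bonds and differ only in configuration as drawn: 1 of 1 stereo elements differ; a stereocentre at a saturated chain carbon is drawn R in compound 2 and S in compound 3. The same atoms and bonds are present; only the drawn configuration of the stereocentre at the saturated chain carbon differs. For the measured compounds named here, no step between measured compounds is available to calibrate such a change, so no step beyond the scatter is expected in this assay; the expected step of a number 1 percentage points lower from compound 2 to compound 3 (within the scatter) is estimated as essentially none. Compound 3 is expected to give about 93%, within 82% to 101%.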

Compound 3, a percentage reported as activity, at one concentration (the size of the read-out at that concentration, not a potency): 92%
The estimate for compound 3 lay 1 percentage points above the measured number, within the range that was stated.
By their numbers in this assay, from the lowest: compounds 1, 3 and 2 (each within the scatter of the next).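

Inverting the drawn configuration at the chain carbinol gives the first step in the series that can be read between two measured compounds: in this assay it is a number 2 percentage points lower from compound 2 to compound 3 (within the scatter). With the rest of the chain unchanged, the R and S drawings of this stereocentre are not separated at the concentration tested, and both remain at the weak end of the read-out. The comparison isolates this stereocentre, since nothing else varies within the pair: the fact that compounds 2 and 3 differ only in the configuration as drawn

Going by these compounds, it remains open whether configuration at this carbon would count for more if the hydroxyl were replaced by an amine or a carboxylic acid, or if the chain were longer. This single pair also cannot show whether the same holds at a concentration other than the one tested.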